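A few compounds are considered here, and "the series" means these few. Any claim that something is new, unique, unknown or untested is made for them only; others in the source may bear on it.

Measured so far in an ADME assay on Huh-7 cells (Homo sapiens) for cytotoxicity, with a stated time of 72 h; a higher number here means that more compound is tolerated, a lower number that less compound is tolerated:

compound 1 `CS(=O)(=O)Nc1ccc2c(c1)S(=O)(=O)N=C(C1=C(O)C3CCCC3N(Cc3ccccn3)C1=O)N2`, a limit only: > 33000 nM

compound 2 `CS(=O)(=O)Nc1ccc2c(c1)S(=O)(=O)N=C(C1=C(O)C3CCCC3N(Cc3ccc(Cl)cc3)C1=O)N2`, a limit only: > 10000 nM

compound 3 `CCN1C(=O)C(C2=NS(=O)(=O)c3cc(NS(C)(=O)=O)ccc3N2)=C(O)C2CCCC21`, a limit only: > 33000 nM

Compound 3 stands at the limit of > 33000 nM in this assay, at which 2 of the 3 values shown sit, the same limit that compound 1 reaches, while compound 2 stops at the limit of > 10000 nM in this assay, at which 1 of the 3 values shown sits. No entry in this assay is a number, so the three compounds cannot be ordered against one another on the values shown.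

The next compound, compound 4 `CS(=O)(=O)Nc1ccc2c(c1)S(=O)(=O)N=C(C1=C(O)C3CCCC3N(CC3CCC3)C1=O)N2`, differs from compound 3 by cyclobutyl in place of methyl on a saturated chain carbon bound to an amide-type nitrogen in a ring.

The measured steps that touch this position are a step that the two limits leave unreadable from compound 1 to compound 3 and a step that the two limits leave unreadable from compound 2 to compound 3; the remaining pair gives a step that the two limits leave unreadable from compound 1 to compound 2. None of them can be read as a size, because both ends of each step are limits, so they offer no direction and no magnitude for this assay. The expected step is a number no higher from compound 3 to compound 4 (the limit leaves the size open), nothing beyond the scatter. Compound 4 is estimated at 33000 nM in this assay, with a range from 12000 nM to 80000 nM, and it is expected that the assay again returns only a limit rather than a number.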

Compound 4, half-maximal cytotoxic concentration: > 33000 nM
Compound 4: only a limit was reported (the forecaster's own chance of this, stated with the estimate: 80%); the middle value lies on the limit itself.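

In this assay, among these compounds, compound 4 gives > 33000 nM, a limit and not a number, so no step linking compound 4 with compound 1, compound 2 or compound 3 can be read. The compounds shown leave open at what concentration any of the four turns cytotoxic, and whether the group on a saturated chain carbon bound to an amide-type nitrogen in a ring alters that concentration at all.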